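Methyl to phenyl on the amide of compound 2

This account rests on a few compounds, and the source may have more. Where it says the series, first, only, none or still open, it means among the compounds named here.

Of the compounds shown here, two have been measured so far in an assay on isolated protein for inhibition of Rho-associated protein kinase 1 (Homo sapiens), read by scintillation counting, radiometric assay and 33P incorporation, with a stated time of 40 min, in the presence of a further agent that is not named here; on this read-out higher numbers stand for weaker inhibition and lower numbers for stronger inhibition. Compound 2 `CC(=O)Nc1cccc(NC(=O)COc2ccc3c(=O)ccoc3c2)c1` gives 2500 nM in this assay. Compound 1 `COc1cc(OCC(=O)Nc2cccc(NC(=O)c3ccc(N(C)C)cc3)c2)ccc1C=O`, built on a different core, gives 3740 nM in this assay. Compound 2 therefore has the lower of the two numbers, but its nearest neighbour, compound 1, lies within the scatter of it, so the two cannot be told apart.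

The next compound, compound 3 `O=C(COc1ccc2c(=O)ccoc2c1)Nc1cccc(NC(=O)c2ccccc2)c1`, keeps the core of compound 2 and alters one group: phenyl in place of methyl on a carbonyl carbon. Within the data shown here, no step between measured compounds covers this change, so no measured precedent exists for it. Compound 1 carries an aryl amide at the same place and does not stand apart from compound 2 in this assay, which argues against a large shift in either direction.

Compound 3 is expected to give about 2000 nM in this assay, with an estimated range from 700 nM to 6000 nM. That estimate means an expected step of a 1.3-fold lower number from compound 2 to compound 3 (0.10 log units; within the scatter), one that is not expected to go beyond the scatter.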

Compound 3, half-maximal inhibitory concentration: 120 nM
Estimate against measurement, compound 3: 17-fold (1.22 log units) above; the measured number lies below the stated range.
By their numbers in this assay, from the lowest: compound 3; then compounds 2 and 1 (each within the scatter of the next).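

In this assay, among these compounds, the change from acetamido to benzamido gives a 21-fold lower number from compound 2 to compound 3 (1.32 log units; beyond the scatter) and is the first change whose effect can be read on its own. The group on this carbonyl carbon, whose other neighbour is the amide-type nitrogen, therefore has a large bearing on the read-out: with the rest of compound 2 held fixed, phenyl in place of methyl alone accounts for the whole of this step. Nothing measured here bears on why the number falls so far.

Among the compounds shown here, the single step leaves open whether the six-membered aromatic ring of carbon is itself required, and whether a cyclohexyl ring, a benzyl group, a pyridine ring, or a phenyl ring carrying an amine or a carboxylic acid would keep, extend or lose the step. It also leaves open whether the step carries over to another core, as compound 1 differs from compound 3 in more than one place and cannot be set against it.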